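Aziridine-nitrile ureas: aryl substituent change on cell inhibition

A few compounds are considered here, and "the series" means these few. Any claim that something is new, unique, unknown or untested is made for them only; others in the source may bear on it.

Measured so far:
compound 1 `N#CC1CN1C(=O)Nc1ccc(F)cc1` — 5900 nM
compound 2 `N#CC1CN1C(N)=O` — 432000 nM

In a functional assay on RPMI-8226 cells (Homo sapiens) for inhibition (a lower number here means a stronger inhibitor, a higher number a weaker inhibitor), compound 1 gives 5900 nM and stands with the lowest of the two numbers. Compound 2, the bare urea without the aryl group, gives 432000 nM in this assay; the two compounds differ in more than one place, so only the two values themselves can be compared, and they lie far apart, beyond the scatter.

The next compound, compound 3 `N#CC1CN1C(=O)Nc1ccc(C(F)(F)F)cc1`, keeps the whole frame of compound 1 and differs only in one place: trifluoromethyl in place of fluoro on an aromatic carbon. For the measured compounds named here, no step between two measured compounds of this kind is at hand, so the size of this change in this assay is not known from the series; the only measured contrast, from compound 1 to compound 2, concerns the presence of the aryl group as a whole, not a substituent on it.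

The expectation is a step from compound 1 to compound 3 of a 1.5-fold lower number from compound 1 to compound 3 (0.17 log units; within the scatter), small and within or close to the scatter, in either direction. For compound 3 the estimated value in this assay is 4000 nM, in the range 1000 nM to 16000 nM.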

Compound 3, half-maximal inhibitory concentration: 7800 nM
For compound 3 the middle estimate is 2.0-fold (0.29 log units) below the measured one; low and high end bracket the measured number.
By their numbers in this assay, from the lowest: compounds 1 and 3 (each within the scatter of the next); then compound 2.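

Trifluoromethyl in place of fluoro gives the first step in the series that concerns a substituent on the aryl group rather than the aryl group as a whole: in this assay it is a 1.3-fold higher number from compound 1 to compound 3 (0.12 log units; within the scatter). At this aromatic carbon, then, a group of 4 heavy atoms can stand in place of a group of 1 heavy atom with no change in the read-out that can be told from the scatter, so this one exchange does not separate the two substituents. No measurement at hand speaks to why the number stays within the scatter across this exchange.

The compounds shown leave open whether this flat result holds for substituents of another kind at the same carbon, such as an amine, a carboxylic acid or a longer alkyl chain, since fluoro and trifluoromethyl are the only two groups compared there. They also leave open what a plain hydrogen at this carbon would give on the core of compound 1, which would show whether a substituent at this place matters at all.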